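From tert-butyl to prop-1-en-1-yl in a small series

A few compounds are considered here, and "the series" means these few. Any claim that something is new, unique, unknown or untested is made for them only; others in the source may bear on it.

Measured so far in a functional assay on HCT-116 cells (Homo sapiens), read by crystal violet staining, with a stated time of 6 days (a lower number here means a stronger inhibitor of growth, a higher number a weaker inhibitor of growth), with these values:
- compound 1 (`COc1ccc([C@@H]2CC(=O)c3c(O)cc(OC(=O)c4ccccc4)cc3O2)cc1O`) gives 16500 nM
- compound 2 (`CCCC(=O)Oc1cc(O)c2c(c1)O[C@H](c1ccc(OC)c(O)c1)CC2=O`) gives 12000 nM
- compound 3 (`COc1ccc([C@@H]2CC(=O)c3c(O)cc(OC(=O)C(C)(C)C)cc3O2)cc1O`) gives 31500 nM

Compound 3 stands at the high end of these three numbers. Its nearest neighbour gives a 1.9-fold higher number from compound 1 to compound 3 (0.28 log units; within the scatter) and its furthest gives a 2.6-fold higher number from compound 2 to compound 3 (0.42 log units; beyond the scatter) as the only clear separation in the set. The remaining pair gives a 1.4-fold lower number from compound 1 to compound 2 (0.14 log units; within the scatter) and so does not separate phenyl from propyl.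

Compound 4 (`C/C=C/C(=O)Oc1cc(O)c2c(c1)O[C@H](c1ccc(OC)c(O)c1)CC2=O`) has not yet been measured. The change is prop-1-en-1-yl in place of tert-butyl on a carbonyl carbon and reads prop-1-en-1-yl in place of tert-butyl on a carbonyl carbon. Among the measured groups, the propyl of compound 2 is closest in name to prop-1-en-1-yl, but no measured compound carries the double bond in this group, which leaves the comparison approximate. The step that bears most on the change is a 2.6-fold higher number from compound 2 to compound 3 (0.42 log units; beyond the scatter) read backwards. The expected step in this assay for compound 4 is a 2.3-fold lower number from compound 3 to compound 4 (0.35 log units; beyond the scatter) and thus similar in size and opposite in direction. For compound 4 the estimate is 14000 nM (7000 nM to 28000 nM).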

Compound 4, concentration for 50% growth inhibition: 16900 nM
Compound 4: middle estimate off by 1.2-fold (0.08 log units), on the low side; the range from low to high includes it.
By their numbers in this assay, from the lowest: compounds 2, 1, 4 and 3 (each within the scatter of the next, the first and the last beyond it).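

In this assay, the step to prop-1-en-1-yl on this carbonyl carbon lies within the scatter from all three earlier groups: tert-butyl (a 1.9-fold lower number from compound 3 to compound 4 (0.27 log units; within the scatter)), propyl (a 1.4-fold higher number from compound 2 to compound 4 (0.15 log units; within the scatter)) and phenyl (a 1.0-fold higher number from compound 1 to compound 4 (0.01 log units; within the scatter)). The double bond therefore brings no separation from the saturated propyl of compound 2, and compound 4 does not stand apart from either end of the one gap beyond the scatter in the series (a 2.6-fold higher number from compound 2 to compound 3 (0.42 log units; beyond the scatter)), so that gap remains the only clear difference at this position and the new group adds no second one. Nothing measured here accounts for any of these numbers or for that single gap.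

Still open, from the compounds shown here alone, is whether any group on this carbonyl carbon can move the number well outside the narrow span of these four compounds, for example a longer chain such as octyl, or a chain ending in an amine or a carboxylic acid. Also open, going by these compounds, is whether the oxygen next to the carbonyl group matters, which an amide nitrogen at that place would test, and how much growth inhibition comes from the shared core alone, which a free hydroxyl in place of the whole acyloxy group would show.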